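One Added Methyl on the Sulfur Chain

The source may report more compounds than this note shows. Statements on the series, on what has been measured and on what is new or still open speak of the compounds shown alone.

Compound 1 `C=CC1C(=O)N(c2cc(OC)c(OC)c(OC)c2)C1c1ccc(SCC)cc1`: 257 nM
Compound 2 `COc1cc(N2C(=O)C(C3CC3)C2c2ccc(SC)cc2)cc(OC)c1OC`: 204 nM

In a functional assay on HT-29 cells (Homo sapiens) for inhibition, read by sulforhodamine B assay, with a stated time of 72 h (on this read-out lower numbers stand for stronger inhibition and higher numbers for weaker inhibition), compound 2 gives 204 nM and stands level, within the scatter, with compound 1 at 257 nM. Compound 3 `CCSc1ccc(C2C(C3CC3)C(=O)N2c2cc(OC)c(OC)c(OC)c2)cc1` differs from compound 2 by methyl in place of hydrogen on a saturated chain carbon bound to a sulfur, which turns methylsulfanyl to ethylsulfanyl. For the measured compounds named here, no measured pair shows this change alone, so the data offer no direct precedent. In this assay, the expected size is a 1.1-fold higher number from compound 2 to compound 3 (0.05 log units; within the scatter), with no step beyond the scatter in either direction. The value expected for compound 3 is 230 nM, with an estimated range from 100 nM to 530 nM.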

Compound 3, half-maximal inhibitory concentration: 1560 nM
Beside the measured number, compound 3's estimate is 6.8-fold (0.83 log units) below it; measured number above the stated range.
By their numbers in this assay, from the lowest: compounds 2 and 1 (each within the scatter of the next); then compound 3.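

In this assay the sulfur chain proves sensitive: methylsulfanyl to ethylsulfanyl gives a 7.6-fold higher number from compound 2 to compound 3 (0.88 log units; beyond the scatter) and shows that one methyl on the saturated chain carbon bound to a sulfur can count for much on this scaffold. With ethylsulfanyl in both, cyclopropyl in place of vinyl on a saturated ring carbon gives a 6.1-fold higher number from compound 1 to compound 3 (0.78 log units; beyond the scatter) and shows that this ring-carbon group matters too. No measurement at hand explains either step.

On these data alone, whether a longer chain such as propylsulfanyl moves the number further remains open. So does how vinyl reads alongside methylsulfanyl.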